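Aromatising the cyclohexenyl ring: compound 1 to compound 4

A few compounds are considered here, and "the series" means these few. Any claim that something is new, unique, unknown or untested is made for them only; others in the source may bear on it.

Compound 1 `COC(=O)C1=C(c2ccc(CNc3nccc(C)c3NC(=O)CC#N)cc2)CCCC1` stands lowest of the two numbers in an assay on isolated protein for binding affinity to B1 bradykinin receptor (Homo sapiens) (on this read-out lower numbers stand for stronger inhibition and higher numbers for weaker inhibition), at 35 nM. Compound 3 `COC(=O)c1ccccc1C1CCC(CNc2nccc(C)c2NC(=O)CC#N)CC1` gives 385 nM in this assay. For compound 2 `COC(=O)C1CCCN1c1ccc(CNc2nccc(C)c2NC(=O)CC#N)cc1` this assay reports only a limit, > 5000 nM. Compound 4 `COC(=O)c1ccccc1-c1ccc(CNc2nccc(C)c2NC(=O)CC#N)cc1` differs from compound 1 in one place: 2-(methoxycarbonyl)phenyl in place of 2-(methoxycarbonyl)cyclohex-1-en-1-yl on an aromatic carbon. Within the data shown here, the single measured step at this position, an at least 140-fold higher number from compound 1 to compound 2 (2.15 log units; beyond the scatter), swapped in a nitrogen-linked saturated ring and was a large loss, whereas the change to compound 4 keeps the carbon-linked six-membered ring and its ester and only makes the ring aromatic. A modest step is therefore expected, a 1.6-fold higher number from compound 1 to compound 4 (0.20 log units; within the scatter), with a slight lean toward weaker binding. Compound 4 is estimated at 55 nM, between 15 nM and 220 nM.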

Compound 4, inhibition constant in the B1 bradykinin receptor assay: 11 nM
Compound 4: the middle estimate sits 5.0-fold (0.70 log units) above what was measured; the whole stated range lies above it.
By their numbers in the B1 bradykinin receptor assay, from the lowest: compound 4; then compound 1; then compound 3. At a limit, above all of these: compound 2.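

In the B1 bradykinin receptor assay, the 2-(methoxycarbonyl)phenyl group does better at this place than the 2-(methoxycarbonyl)cyclohex-1-en-1-yl group, with a 3.2-fold lower number from compound 1 to compound 4 (0.50 log units; beyond the scatter), so a non-aromatic ring is not required here. The step of an at least 450-fold lower number from compound 2 to compound 4 (2.65 log units; beyond the scatter) starts from a limit for compound 2 and shows how far the two replacements at this place stand apart. The lower number comes with lower lipophilicity: in a physicochemical assay for lipophilicity (a higher number here means a more lipophilic compound, a lower number a more polar compound), compound 1 gives 3 and compound 4 gives 2.5.

On these data alone, whether a carboxylic acid or a primary amide could stand in for the methoxycarbonyl group on the phenyl ring remains open.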